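Replacing 4-bromophenyl with 3-methoxyphenyl in a cytotoxicity series

The source may hold more compounds than are shown below. What is called first, only, known or untested is meant among the compounds shown, and "the series" means these compounds.

Measured in a functional assay on HCT-116 cells (Homo sapiens) for cytotoxicity, read by cell counting, with a stated time of 48 h; on this read-out lower numbers stand for stronger inhibition and higher numbers for weaker inhibition:
- Compound 1 `Cc1ccc(-n2cc(COc3cccc4cnc(Nc5cccc(Cl)c5)nc34)nn2)c([N+](=O)[O-])c1`: > 25000 nM (a limit of the assay)
- Compound 2 `Clc1ccc(-n2cc(COc3cccc4cnc(Nc5cccc(Cl)c5)nc34)nn2)cc1`: > 25000 nM (a limit of the assay)
- Compound 3 `Clc1cccc(Nc2ncc3cccc(OCc4cn(-c5ccc(Br)cc5)nn4)c3n2)c1`: 17000 nM

Going by the values given here, compound 3 gives 17000 nM, the only actual number in the set. The other two compounds stand at the limit of > 25000 nM in this assay, at which 2 of the 3 values shown sit.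

Compound 4 `COc1cccc(-n2cc(COc3cccc4cnc(Nc5cccc(Cl)c5)nc34)nn2)c1` has not yet been measured. It carries 3-methoxyphenyl in place of 4-bromophenyl on an aromatic nitrogen. Among the compounds with values here, none of the measured compounds carries this group, so the evidence is indirect.

Within the data shown here, three measured steps concern the same place. One is an at least 1.4-fold lower number from compound 1 to compound 3 (0.16 log units; that floor lies within the scatter). Another is an at least 1.4-fold lower number from compound 2 to compound 3 (0.16 log units; that floor lies within the scatter). The third is a step that the two limits leave unreadable from compound 1 to compound 2. The first two give only floors, and the third gives no readable size.

The expectation therefore rests on compound 3 at 17000 nM and on those floors, which stay within the scatter. No step beyond the scatter is expected in this assay, and a result reported only as a limit would fit the set. The expected step is a 1.3-fold higher number from compound 3 to compound 4 (0.11 log units; within the scatter). Compound 4 is estimated at 22000 nM, with an expected range from 9000 nM to 45000 nM.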

Compound 4, half-maximal inhibitory concentration: 23000 nM
The estimate for compound 4 lay 1.0-fold (0.02 log units) below the measured number, within the range that was stated.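

In this assay, exchanging 4-bromophenyl for 3-methoxyphenyl on the aromatic nitrogen of the five-membered ring gives a 1.4-fold higher number from compound 3 to compound 4 (0.13 log units; within the scatter), so this change, which adds an oxygen and a hydrogen-bond acceptor to the group, does not move the number beyond the scatter. Compound 4 is the second compound in the set with a readable number, so a readable value at this position is no longer tied to 4-bromophenyl alone. Against the other two compounds there are only floors, an at least 1.0-fold lower number from compound 2 to compound 4 (0.03 log units; that floor lies within the scatter) and an at least 1.0-fold lower number from compound 1 to compound 4 (0.03 log units; that floor lies within the scatter), and they stay floors because those two compounds rest on a limit: the limit of > 25000 nM in this assay, at which 2 of the 4 values shown sit.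

The compounds shown leave open whether any group at this position can shift the number beyond the scatter, for example a phenyl ring carrying an amine or a carboxylic acid, or a longer chain in place of the phenyl ring. The shared core is the same in every compound shown, so its part in the number remains untested.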